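Swapping Halogenated Phenyl Groups: What to Expect for Compound 4

A few compounds are considered here, and "the series" means these few. Any claim that something is new, unique, unknown or untested is made for them only; others in the source may bear on it.

Of the compounds shown here, three have so far been tested in a functional assay on the whole organism (Abdomen, strain Swiss) for inhibition, with Mus musculus as the target, with stated times of 30 min, 10 min and 5 min, at a dose of 40 mg/kg by the oral route; a higher number here means a stronger effect of the compound at the dose given, a lower number a weaker effect. Compound 1 `Cc1c(C#N)c(-c2ccccc2)nn1CCCN1CCN(c2ccc(F)cc2)CC1` gives 51%. Compound 2 `Cc1c(C#N)c(-c2ccccc2)nn1CCCN1CCN(c2cccc(Cl)c2)CC1` carries one change, (3-chlorophenyl in place of 4-fluorophenyl on an amine nitrogen in a ring), and in this assay compound 2 gives 23%, a step of a number 28 percentage points lower from compound 1 to compound 2 (beyond the scatter). Compound 3 `CC(=O)c1cccn1CCCN1CCN(c2ccc(F)cc2)CC1` is built on a different core, and the difference between the two cores is not broken down here. In this assay compound 3 gives 38%, which places it below compound 1 and above compound 2, both gaps lying beyond the scatter.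

Compound 4 `CC(=O)c1cccn1CCCN1CCN(c2cccc(Cl)c2)CC1` has not yet been measured. It differs from compound 3 by 3-chlorophenyl in place of 4-fluorophenyl on an amine nitrogen in a ring, the same change, at the same place, that turns compound 1 into compound 2. Among the compounds with values here, because the single earlier example gave a number 28 percentage points lower from compound 1 to compound 2 (beyond the scatter), a step of similar size is expected for the new pair, though one example is a thin basis. The expected step is a number 24 percentage points lower from compound 3 to compound 4 (beyond the scatter). Compound 4 is therefore estimated to give 14% in this assay, with a likely range from 0% to 34%.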

Compound 4, a percentage reported as inhibition, in the whole organism at one dose (the size of the read-out at that dose, not a potency): 54%
Estimate against measurement, compound 4: 40 percentage points below; the whole stated range lies below it.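

In this assay, putting 3-chlorophenyl in place of 4-fluorophenyl gives a number 16 percentage points higher from compound 3 to compound 4 (beyond the scatter) and so runs in the opposite direction to the earlier step. Set side by side, the two results show that this change does not carry over from one core to the other: the same change on two cores in this assay, a number 28 percentage points lower (beyond the scatter) from compound 1 to compound 2 and a number 16 percentage points higher (beyond the scatter) from compound 3 to compound 4, 44 percentage points apart, beyond the scatter of two such steps. This shows that, for these two pairs, the outcome of the swap depends on the core it is made on, but it does not show which part of the cores is responsible, and two pairs give no rule for predicting the step on any further core.

The swap also alters both the halogen and its place on the phenyl ring, and the compounds shown leave open which of the two matters on each core. They also leave open how a plain phenyl group or a methoxyphenyl group on the ring nitrogen, or a longer chain joining the core to the six-membered ring, would behave on these two cores.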